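The source may report more compounds than this note shows. Statements on the series, on what has been measured and on what is new or still open speak of the compounds shown alone.

Measured in an assay on isolated protein for inhibition of alpha-galactosidase A (Homo sapiens), read by fluorescence, tested at 100 uM; on this read-out lower numbers stand for less inhibition and higher numbers for more inhibition at the one concentration tested (going by the name of the read-out):
- compound 1 `NC[C@@H]1NC[C@H](O)[C@H](O)[C@H]1O`: 45%
- compound 2 `COc1ccc(Br)cc1/C=C/C(=O)NC[C@H]1NC[C@H](O)[C@@H](O)[C@H]1O`: 99%
- compound 3 `COc1ccc(OC)c(/C=C/C(=O)NC[C@H]2NC[C@H](O)[C@@H](O)[C@H]2O)c1`: 99%

Compound 2 stands level with compound 3 at the digits shown, the two together the highest of the three numbers; compound 1, the shared core alone, lies far lower. Next is compound 4 `O=C(/C=C/c1cccc(Br)c1)NC[C@H]1NC[C@H](O)[C@@H](O)[C@H]1O`, differing from compound 2 by hydrogen in place of methoxy on an aromatic carbon. For the measured compounds named here, the only measured step, no change at the digits printed from compound 2 to compound 3 (within the scatter), also sits on the aromatic ring and bears on this one: a change there left the reading where it was, and the reading is already near the top of the scale. A step in the same place is therefore expected to be a number 4 percentage points lower from compound 2 to compound 4 (within the scatter), that is, nothing beyond the scatter in this assay. Compound 4 is estimated at 95%, with a range from 85% to 100%.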

Compound 4, a percentage reported as inhibition, at one concentration (the size of the read-out at that concentration, not a potency): 99%
Compound 4: middle estimate off by 4 percentage points, on the low side; the range from low to high includes it.
By their numbers in this assay, from the lowest: compound 1; then compounds 2, 3 and 4 (each within the scatter of the next).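

In this assay, hydrogen can stand in place of the methoxy group, ortho to a large group and para to the bromo group, with the reading unmoved: no change at the digits printed from compound 2 to compound 4 (within the scatter). The earlier step changed the bromo group, whereas this one shows that the methoxy group is not required for the reading at this one concentration. No available evidence bears on this result.

With compound 2 at 99% and compound 4 at 99%, both readings lie close to the top of the scale, so any difference in potency stays hidden. On these data alone, whether an amine or a carboxylic acid on this aromatic carbon would lower the reading remains open.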